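The compounds below may be only part of what the source reports. "The series", "measured", "known", "first", "only" and "open" are said of these compounds alone.

Measured so far in an assay on NIH3T3 cells with Urotensin-2 receptor (Homo sapiens) as the target; on this read-out lower numbers stand for an effect already at smaller amounts and higher numbers for an effect only at larger amounts of compound:
compound 1 `Cc1ccccc1C(=O)NC(CCN(C)C)c1ccc(Cl)cc1`: 3550 nM
compound 2 `Cc1cccc(C(=O)NC(CCN(C)C)c2ccc(Cl)cc2)c1C`: 3630 nM
compound 3 `Cc1c(Cl)cccc1C(=O)NC(CCN(C)C)c1ccc(Cl)cc1`: 1740 nM

Compound 3 stands lowest of the three in this assay: a 2.0-fold lower number from compound 1 to compound 3 (0.31 log units; beyond the scatter) and a 2.1-fold lower number from compound 2 to compound 3 (0.32 log units; beyond the scatter), both modest but beyond the scatter. Compound 4 `Cc1ccc(C)c(C(=O)NC(CCN(C)C)c2ccc(Cl)cc2)c1` differs from compound 3 by 2,5-dimethylphenyl in place of 3-chloro-2-methylphenyl on a carbonyl carbon. Two of the measured steps bear on this change. The chloro that gave compound 3 its lower number leaves again, so those two steps should run in reverse. The added methyl, judged by a 1.0-fold higher number from compound 1 to compound 2 (0.01 log units; within the scatter), changed nothing beyond the scatter. Compound 4 is therefore expected to sit near compounds 1 and 2 in this assay, at an estimated 3500 nM with a range of 1700 nM to 7000 nM. That estimate means a 2.0-fold higher number from compound 3 to compound 4 (0.30 log units; within the scatter).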

Compound 4, half-maximal effective concentration: 2880 nM
Beside the measured number, compound 4's estimate is 1.2-fold (0.08 log units) above it; measured number inside the range.
By their numbers in this assay, from the lowest: compounds 3, 4, 1 and 2 (each within the scatter of the next, the first and the last beyond it).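

In this assay the added methyl gives a 1.2-fold lower number from compound 1 to compound 4 (0.09 log units; within the scatter) and the shift from 2,3-dimethylphenyl to 2,5-dimethylphenyl gives a 1.3-fold lower number from compound 2 to compound 4 (0.10 log units; within the scatter) so neither methyl pattern separates from the unsubstituted-at-that-place compound 1. Putting 2,5-dimethylphenyl in place of 3-chloro-2-methylphenyl gives a 1.7-fold higher number from compound 3 to compound 4 (0.22 log units; within the scatter) so, unlike compounds 1 and 2, compound 4 cannot be told apart from compound 3, and the chloro's advantage does not hold against this dimethyl pattern. On these data alone, what a methoxy group or an amine on this ring would do stays open. Nothing shown here explains these numbers.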